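Thiophene amide replacing cyclopropyl amide in an oxadiazole urea series

The source may report more compounds than this note shows. Statements on the series, on what has been measured and on what is new or still open speak of the compounds shown alone.

Measured compounds:
compound 1 `O=C(Nc1cccc(-c2nc(-c3ccc(NC(=O)c4cccnc4)cc3Cl)no2)c1)Nc1cccc(C(F)(F)F)c1` 1900 nM
compound 2 `COc1ccc(NC(=O)Nc2cccc(-c3nc(-c4ccc(NC(=O)c5cccnc5)cc4Cl)no3)c2)cc1C(F)(F)F` 1700 nM
compound 3 `O=C(Nc1cccc(-c2nc(-c3ccc(NC(=O)c4cccnc4)cc3Cl)no2)c1)Nc1ccc(NC(=O)C2CC2)c(C(F)(F)F)c1` 200 nM

In a functional assay on MDA-MB-231 cells (Homo sapiens) for antiproliferative activity, read by MTT assay, with a stated time of 72 h (on this read-out lower numbers stand for stronger inhibition and higher numbers for weaker inhibition), compound 3 gives the lowest of the three numbers: a 9.5-fold lower number from compound 1 to compound 3 (0.98 log units; beyond the scatter) and an 8.5-fold lower number from compound 2 to compound 3 (0.93 log units; beyond the scatter), while a 1.1-fold lower number from compound 1 to compound 2 (0.05 log units; within the scatter). Compound 4 `O=C(Nc1cccc(-c2nc(-c3ccc(NC(=O)c4cccnc4)cc3Cl)no2)c1)Nc1ccc(NC(=O)c2cccs2)c(C(F)(F)F)c1` differs from compound 3 by thiophen-2-yl in place of cyclopropyl on a carbonyl carbon. For the measured compounds named here, none of the measured steps touches the group on this carbonyl carbon; the two larger steps, from compound 1 and from compound 2 to compound 3, concern only the presence of the (cyclopropylcarbonyl)amino group. Going by the values given here, with no precedent for exchanging the acyl group, compound 4 is expected to stay close to compound 3, a 1.3-fold higher number from compound 3 to compound 4 (0.10 log units; within the scatter), within the scatter. Compound 4 is therefore estimated at 250 nM, with a range from 80 nM to 800 nM.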

Compound 4, half-maximal inhibitory concentration: 2900 nM
Estimate against measurement, compound 4: 12-fold (1.06 log units) below; measured number above the stated range.
By their numbers in this assay, from the lowest: compound 3; then compounds 2, 1 and 4 (each within the scatter of the next).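

In this assay, the group on this carbonyl carbon matters: thiophen-2-yl in place of cyclopropyl gives a large loss (a 15-fold higher number from compound 3 to compound 4 (1.16 log units; beyond the scatter)). The acylamino group as such therefore does not secure the lower number, for ((thiophen-2-yl)carbonyl)amino stays within the scatter of both hydrogen (a 1.5-fold higher number from compound 1 to compound 4 (0.18 log units; within the scatter)) and methoxy (a 1.7-fold higher number from compound 2 to compound 4 (0.23 log units; within the scatter)). No evidence is available to account for this result.

Going by these compounds, it remains open whether methyl, cyclobutyl, phenyl or furan-2-yl on this carbonyl carbon would track cyclopropyl or thiophen-2-yl.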